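Two amines on a shared core, one still unmeasured

This account rests on a few compounds, and the source may have more. Where it says the series, first, only, none or still open, it means among the compounds named here.

- Compound 1 `Cc1ccc2[nH]c(C(=O)N[C@H]3CN(S(=O)(=O)c4ccccc4)C[C@@H]3C(=O)N[C@H]3CCCN(C)C3)cc2c1`: 0.3 10^-6 cm/s
- Compound 2 `O=C(N[C@H]1CN(S(=O)(=O)c2ccccc2)C[C@@H]1C(=O)NC[C@@H]1CCCN1)c1cc(-c2ccccc2Cl)on1`: 0.44 10^-6 cm/s

Only these two compounds have been measured so far in an ADME assay on Caco-2 cells (Homo sapiens) for permeability, in the apical to basolateral direction, at pH 7.4; a higher number here means that the compound crosses the layer faster, a lower number that the compound crosses the layer more slowly. Compound 2 gives 0.44 10^-6 cm/s and compound 1 gives 0.3 10^-6 cm/s, and these two values lie within the usual scatter of each other. Among the compounds with values here, compound 2 therefore does not stand apart from the only other compound measured.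

The next compound is compound 3 `CN1CCC[C@H](NC(=O)[C@H]2CN(S(=O)(=O)c3ccccc3)C[C@@H]2NC(=O)c2cc(-c3ccccc3Cl)on2)C1`, which has 1-methylpiperidin-3-yl in place of the (pyrrolidin-2-yl)methyl of compound 2 on an amide-type nitrogen (1-methylpiperidin-3-yl in place of (pyrrolidin-2-yl)methyl on an amide-type nitrogen). Within the data shown here, no measured pair shows this change alone, so the data give no direct size for it. Among the measured compounds shown here, the only guide is that both measured values sit close together, with compound 1 at 0.3 10^-6 cm/s and compound 2 at 0.44 10^-6 cm/s. On that basis, no step beyond the scatter is expected in this assay, and no clear direction can be expected either. The estimated change is a 1.1-fold lower number from compound 2 to compound 3 (0.04 log units; within the scatter). For compound 3 the expected value is 0.4 10^-6 cm/s, with an estimated range of 0.17 10^-6 cm/s to 1 10^-6 cm/s.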

Compound 3, apparent permeability: 1.3 10^-6 cm/s
The estimate for compound 3 lay 3.3-fold (0.51 log units) below the measured number; measured number above the stated range.
By their numbers in this assay, from the lowest: compounds 1 and 2 (each within the scatter of the next); then compound 3.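

In this assay, within the data shown here, the place on the amide-type nitrogen now has a step that can be read: 1-methylpiperidin-3-yl in place of (pyrrolidin-2-yl)methyl gives a difference beyond the scatter (a 3.0-fold higher number from compound 2 to compound 3 (0.47 log units; beyond the scatter)), whereas the earlier compounds offered no pair that isolated this change. With 1-methylpiperidin-3-yl held constant, the carbonyl carbon also proves to be a place where the number moves, as the group of 12 heavy atoms in place of the group of 10 heavy atoms gives a second step beyond the scatter (a 4.3-fold higher number from compound 1 to compound 3 (0.64 log units; beyond the scatter)). Nothing shown here gives a reason for either step.

The change from compound 2 to compound 3 alters the ring size, the hydrogen-bond donor count and the methyl together, so the compounds shown cannot assign the step to any one of these. On these data alone, whether piperidin-3-yl or (1-methylpyrrolidin-2-yl)methyl on the same nitrogen would give a number closer to that of compound 3 or to that of compound 2 remains open.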